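A Benzyl Group Replaces the Carbamoyl on the Ring Amine

This account rests on a few compounds, and the source may have more. Where it says the series, first, only, none or still open, it means among the compounds named here.

Compound 1 `COc1ccc(-c2cnc3nc(N)nc(N4CCN(c5ccc(F)cc5)CC4)c3n2)cc1OC`: 100 nM in a functional assay on cells (T-cell, Homo sapiens) for inhibition; on this read-out lower numbers stand for stronger inhibition and higher numbers for weaker inhibition
Compound 2 `COc1ccc(-c2cnc3nc(N)nc(N4CCN(C(=O)Nc5ccc(F)cc5)CC4)c3n2)cc1OC`: 7 nM in this assay

Compound 2 shows the lower of the two numbers; the difference is a 14-fold lower number from compound 1 to compound 2 (1.15 log units; beyond the scatter). Compound 3 `COc1ccc(-c2cnc3nc(N)nc(N4CCN(Cc5ccc(C(C)(C)C)cc5)CC4)c3n2)cc1OC` differs from compound 2 in one place: 4-(tert-butyl)benzyl in place of (4-fluorophenyl)carbamoyl on an amine nitrogen in a ring. For the measured compounds named here, the single measured step concerns the arrival of the (4-fluorophenyl)carbamoyl, not the 4-(tert-butyl)benzyl now entering, so it bears on compound 3 only loosely. Still, because that carbamoyl brought a 14-fold lower number from compound 1 to compound 2 (1.15 log units; beyond the scatter), its departure is expected to raise the number. Compound 3 is estimated at 60 nM, within 15 nM to 250 nM. This is expected to mean an 8.6-fold higher number from compound 2 to compound 3 (0.93 log units; beyond the scatter).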

Compound 3, half-maximal inhibitory concentration: 4300 nM
For compound 3 the middle estimate is 72-fold (1.86 log units) below the measured one; the whole stated range lies below it.
By their numbers in this assay, from the lowest: compound 2; then compound 1; then compound 3.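

In this assay, the group on this ring amine nitrogen can also move the number sharply upward: 4-(tert-butyl)benzyl in place of (4-fluorophenyl)carbamoyl gives a 610-fold higher number from compound 2 to compound 3 (2.79 log units; beyond the scatter). The same group in place of 4-fluorophenyl gives a 43-fold higher number from compound 1 to compound 3 (1.63 log units; beyond the scatter), so compound 3 does not merely lose the gain seen with the carbamoyl but ends well beyond compound 1. No measured evidence explains this result.

The compounds shown leave open whether the rise follows the tert-butyl or the benzyl link itself. A plain benzyl or 4-fluorobenzyl group on this nitrogen would separate the two.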